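The compounds below may be only part of what the source reports. "The series", "measured", "known", "first", "only" and "open" are said of these compounds alone.

Compound 2 `CCCn1c(=O)c2nc(-c3cnn(Cc4ccccc4C(F)(F)F)c3)[nH]c2n(CCC)c1=O` gives 37 nM in an in vitro assay on HEK293 cells for displacement of a labelled ligand from adenosine receptor A2b (Homo sapiens); a higher number here means a weaker inhibitor, a lower number a stronger inhibitor. For the measured compounds named here, of the two numbers measured so far, compound 2 holds the highest, but its only neighbour sits close: compound 1 `CCCn1c(=O)c2nc(-c3cnn(Cc4cc(C(F)(F)F)ccc4Cl)c3)[nH]c2n(CCC)c1=O` gives 22 nM in this assay, and the step of a 1.7-fold higher number from compound 1 to compound 2 (0.23 log units; within the scatter) falls within the scatter, so the two are not told apart.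

Compound 3 `CCCn1c(=O)c2nc(-c3cnn(Cc4c(F)cccc4F)c3)[nH]c2n(CCC)c1=O` is not yet measured. Against compound 2 it differs in one place: 2,6-difluorophenyl in place of 2-(trifluoromethyl)phenyl on a saturated chain carbon bound to an aromatic nitrogen.

Going by the values given here, only one measured step bears on this change. It, too, exchanges the ring on the saturated chain carbon bound to an aromatic nitrogen while leaving the shared core untouched, and it came out as a 1.7-fold higher number from compound 1 to compound 2 (0.23 log units; within the scatter), within the scatter. That is a thin basis, but it is the whole of it. On this basis the change to compound 3 is not expected to move the number beyond the scatter in this assay; the step of a 1.2-fold lower number from compound 2 to compound 3 (0.09 log units; within the scatter) is expected to be small, in no firm direction. For compound 3 the estimate in this assay is 30 nM, with a range from 10 nM to 90 nM.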

Compound 3, inhibition constant: 390 nM
The estimate for compound 3 lay 13-fold (1.11 log units) below the measured number, outside the stated range (above it).
By their numbers in this assay, from the lowest: compounds 1 and 2 (each within the scatter of the next); then compound 3.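

In this assay, for the compounds shown here, the ring on a saturated chain carbon bound to an aromatic nitrogen proves far from indifferent: 2,6-difluorophenyl in place of 2-(trifluoromethyl)phenyl gives an 11-fold higher number from compound 2 to compound 3 (1.02 log units; beyond the scatter), and in place of 2-chloro-5-(trifluoromethyl)phenyl it gives an 18-fold higher number from compound 1 to compound 3 (1.25 log units; beyond the scatter), whereas the only earlier exchange at this place stayed within the scatter. Among these three compounds, the two rings carrying trifluoromethyl cannot be told apart, while compound 3, which has no trifluoromethyl and carries two fluorines instead, is the weakest inhibitor. No measurement is available here that accounts for this drop.

The compounds shown leave open whether the drop goes with the absence of trifluoromethyl or with the presence of the two fluorines, since compound 3 changes both at once. A plain phenyl, a 2-fluorophenyl or a 2-chlorophenyl on the same chain carbon would help separate these two readings, and a 2-methoxyphenyl would show whether a group other than a halogen or trifluoromethyl is tolerated at this place.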